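The compounds below may be only part of what the source reports. "The series", "measured", "known", "first", "only" and "open" are said of these compounds alone.

Measured compounds:
Compound 1 `Cc1ccc(-n2nncc2CN2C(=O)C3(C(C#N)=C(N)Oc4c3c3nc5ccccc5nc3c3ccccc43)c3ccccc32)cc1Cl` gives in an ADME assay on HUVEC cells (Homo sapiens) for antiproliferative activity, read by MTT assay, with a stated time of 48 h (on this read-out higher numbers stand for weaker inhibition and lower numbers for stronger inhibition), a result that is a limit of the assay, > 50000 nM.
Compound 2 `Cc1ccc(-n2nncc2CN2C(=O)C3(C(C#N)=C(N)Oc4c(N)cc5nc6ccccc6nc5c43)c3ccccc32)cc1C` gives in this assay a result that is also a limit of the assay, > 50000 nM.

Going by the values given here, compound 2 therefore stands at the edge of what this assay can report; no number was reached for it, and the same holds for the only other compound measured, as the shared the limit of > 50000 nM in this assay, at which 2 of the 2 values shown sit, shows. With both results being limits, nothing can be said about a difference between compound 1 and compound 2 beyond that each sits at the limit.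

Compound 3 `COc1cc(-n2nncc2CN2C(=O)C3(C(C#N)=C(N)Oc4c(N)cc5nc6ccccc6nc5c43)c3ccccc32)c(OC)cc1Cl` is the next compound, not yet measured. It differs from compound 2 by 4-chloro-2,5-dimethoxyphenyl in place of 3,4-dimethylphenyl on an aromatic nitrogen. Among the compounds with values here, no step between two measured compounds is available to gauge the effect of such a change, so the expectation for compound 3 rests on the two limits alone. The step from compound 2 to compound 3 is expected to be none beyond the scatter, a number no higher from compound 2 to compound 3 (the limit leaves the size open). Compound 3 is thus estimated to give in this assay about 50000 nM, within a range from 15000 nM to 100000 nM, most probably reported again as a limit.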

Compound 3, half-maximal inhibitory concentration: > 50000 nM
Compound 3: no number, only a limit (the forecaster's own chance of this, stated with the estimate: 85%); the middle value sits exactly at the limit.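

No step can be read between compound 2 and compound 3, since both results in this assay are limits and not numbers: the limit of > 50000 nM in this assay, at which 3 of the 3 values shown sit. The compounds shown leave open how strongly any of them inhibits in this assay and whether 4-chloro-2,5-dimethoxyphenyl in place of 3,4-dimethylphenyl changes the result at all.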